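This account rests on a few compounds, and the source may have more. Where it says the series, first, only, none or still open, it means among the compounds named here.

The study concerns three compounds that share one core. Compound 1, `C/C(=N/NC(=O)c1ccncc1)c1ccc(N/C(S)=N/c2ccccc2)cc1`, is the simplest of them. In a functional assay on Vero cells (Chlorocebus sabaeus) for inhibition, read by MTT assay (a higher number here means a weaker inhibitor, a lower number a stronger inhibitor), compound 1 gives 160000 nM. Compound 2, `COc1ccc(N/C(S)=N\c2ccc(/C(C)=N\NC(=O)c3ccncc3)cc2)cc1`, carries a 4-methoxyphenyl group in place of the plain aryl of compound 1. In this assay compound 2 reaches only a limit of the assay, reported as > 149000 nM, and no number is known for it. That is the limit of > 149000 nM in this assay, at which 1 of the 2 values shown sits, so compound 2 stands at the edge of what this assay can report, while compound 1 has a measured value close to that edge.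

Compound 3, `CCOc1ccc(N/C(S)=N\c2ccc(/C(C)=N\NC(=O)c3ccncc3)cc2)cc1`, has not yet been measured in this assay. It differs from compound 2 by methyl in place of hydrogen on a saturated chain carbon bound to an oxygen on an aromatic ring. Going by the values given here, no step between two measured compounds is available, and compound 2 offers only a limit, so the direction of the change cannot be read from the data. The step from compound 2 to compound 3 is expected to be a step that the limit leaves unreadable from compound 2 to compound 3, that is, no change beyond the scatter. Compound 3 is therefore estimated at 200000 nM, with a range from 80000 nM to 500000 nM, and a limit rather than a number is thought likely.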

Compound 3, half-maximal inhibitory concentration: 144000 nM
Estimate against measurement, compound 3: 1.4-fold (0.14 log units) above; measured number inside the range.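

In this assay the change from 4-methoxyphenyl to 4-ethoxyphenyl, methyl in place of hydrogen on a saturated chain carbon bound to an oxygen on an aromatic ring, amounts to an at least 1.0-fold lower number from compound 2 to compound 3 (0.01 log units; that floor lies within the scatter). This is only a floor that lies within the scatter, so the data neither show a real change nor rule out a larger one, and the true size of the step stays unknown for this reason: the limit of > 149000 nM in this assay, at which 1 of the 3 values shown sits. Going by these compounds alone, what the earlier compounds did not give is a number for an alkoxy group at this place, since compound 3 reads 144000 nM, and so this place can carry an ethoxy group and still return a measured value in this assay, though one that remains close to the edge of what can be reported.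

The compounds shown leave open whether a longer chain on this oxygen, such as propoxy or butoxy, would move the number clearly away from that edge. They also leave open what an amine or a carboxylic acid in place of the alkoxy group would do in this assay.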